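From compound 2 to compound 4: a ring replaces the chain

The source may hold more compounds than are shown below. What is called first, only, known or untested is meant among the compounds shown, and "the series" means these compounds.

Measured in a functional assay on MCF7 cells (Homo sapiens) for inhibition, read by sulforhodamine B assay, with a stated time of 48 h; on this read-out lower numbers stand for stronger inhibition and higher numbers for weaker inhibition:
- compound 1 `CCNC(=O)Nc1ccc(/C=C/c2cccc(Cl)c2)cc1`: 20000 nM
- compound 2 `CCNC(=O)Nc1ccc(/C=C\c2cccc(Cl)c2)cc1`: 32000 nM
- compound 3 `COc1cc(/C=C/c2ccc(N3CCNC3=O)cc2)cc(OC)c1OC`: 540 nM

Compound 2 sits at the high end with compound 1, within the scatter of it, while compound 3 lies lower, beyond the scatter. Compound 4 `O=C1NCCN1c1ccc(/C=C\c2cccc(Cl)c2)cc1` keeps the core of compound 2, with 2-oxoimidazolidin-1-yl in place of (ethylcarbamoyl)amino on an aromatic carbon. Within the data shown here, the only measured step, a 1.6-fold higher number from compound 1 to compound 2 (0.20 log units; within the scatter), concerns the double bond configuration and leaves this group untouched, so it gives no size for this change. No step beyond the scatter is therefore expected in this assay. The estimated step is a 1.6-fold lower number from compound 2 to compound 4 (0.20 log units; within the scatter). For compound 4 the expected value is 20000 nM, with an estimated range of 6000 nM to 50000 nM.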

Compound 4, half-maximal inhibitory concentration: 38 nM
Estimate against measurement, compound 4: 530-fold (2.72 log units) above, and the stated range ends above it.
By their numbers in this assay, from the lowest: compound 4; then compound 3; then compounds 1 and 2 (each within the scatter of the next).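

In this assay, replacing (ethylcarbamoyl)amino with 2-oxoimidazolidin-1-yl on the aromatic carbon gives an 840-fold lower number from compound 2 to compound 4 (2.93 log units; beyond the scatter), so this position responds strongly to the change, unlike the double bond configuration. The two groups hold the same heavy atoms, and they differ in the five-membered non-aromatic ring and in having 2 hydrogen-bond donors against 1 hydrogen-bond donor. Nothing measured here accounts for the size of this step. Open, on these data alone, is whether the ring itself or the missing amide hydrogen carries the step, which a methyl group on the ring nitrogen would test. Also open, as far as these compounds go, is whether the step holds on the E double bond of compound 1.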